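Growth inhibition notes: from compound 3 to compound 4

The source may hold more compounds than are shown below. What is called first, only, known or untested is meant among the compounds shown, and "the series" means these compounds.

Measured in a functional assay on DU-145 cells (Homo sapiens) for inhibition, read by trypan blue exclusion, with a stated time of 96 h; a higher number here means a weaker inhibitor of growth, a lower number a stronger inhibitor of growth:
- compound 1 `O=C(/C(=C\c1ccc(O)c([N+](=O)[O-])c1)SCc1ccccc1Cl)c1ccc(Cl)cc1` gives 10000 nM
- compound 2 `O=C(/C(=C\c1ccc(O)c([N+](=O)[O-])c1)SCc1ccc(Br)cc1)c1ccc(Cl)cc1Cl` gives 10000 nM
- compound 3 `O=C(/C(=C\c1csc([N+](=O)[O-])c1)S(=O)(=O)c1ccc(Br)cc1)c1ccc(Br)cc1` gives 1000 nM

Compound 3 holds the lowest number of the three in this assay, and the gap to each of the other two lies beyond the usual scatter. The next compound to be tested is compound 4 `O=C(/C(=C\c1ccc(F)cc1F)S(=O)(=O)c1ccc(Br)cc1)c1ccc(Br)cc1`, which has 2,4-difluorophenyl in place of 5-nitrothiophen-3-yl on a double-bonded chain carbon bound to a double-bonded chain carbon. The rest of compound 3 stays as it is.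

Within the data shown here, no measured pair in this set differs in one place only, so the size of this step has no direct support. Among the measured compounds shown here, the only guide is the spread between compound 3 at 1000 nM and compound 2 at 10000 nM. A moderate move toward a higher number, meaning weaker inhibition of growth, is expected, and it may not clear the scatter by much. The expected step is a 3.0-fold higher number from compound 3 to compound 4 (0.48 log units; beyond the scatter). For compound 4 the estimate is 3000 nM, with an expected range from 800 nM to 10000 nM.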

Compound 4, concentration for 50% growth inhibition: 7500 nM
The estimate for compound 4 lay 2.5-fold (0.40 log units) below the measured number, within the range that was stated.
By their numbers in this assay, from the lowest: compound 3; then compounds 4, 1 and 2 (each within the scatter of the next).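

In this assay, among these compounds, the only single-place comparison available gives a 7.5-fold higher number from compound 3 to compound 4 (0.88 log units; beyond the scatter), so at this position, on a double-bonded chain carbon bound to a double-bonded chain carbon, the change from 5-nitrothiophen-3-yl to 2,4-difluorophenyl weakens growth inhibition beyond the scatter. The two groups have equal heavy-atom counts but differ in ring size, in hetero atoms and in hydrogen-bond acceptors, and this one step cannot separate these differences. Nothing measured here accounts for the step.

On these data alone, it remains open whether the difference follows the nitro group, the thiophene ring or the two fluorines. A plain thiophen-3-yl, or a phenyl carrying an amine or a carboxylic acid on the same carbon, would help separate these readings.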